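From compound 2 to compound 3: working notes

This account rests on a few compounds, and the source may have more. Where it says the series, first, only, none or still open, it means among the compounds named here.

In a functional assay on HEL cells (Homo sapiens) (a lower number here means that less compound is tolerated, a higher number that more compound is tolerated), compound 2 `CC(=O)NC1=CS(=O)(=O)O[C@@]12[C@@H](CO[Si](C)(C)C(C)(C)C)O[C@@H](n1cc(C)c(=O)n(C)c1=O)[C@@H]2O[Si](C)(C)C(C)(C)C` gives > 200000 nM, which is a limit and not a number. Compound 1 `Cc1cn([C@@H]2O[C@H](CO[Si](C)(C)C(C)(C)C)[C@@]3(OS(=O)(=O)C=C3NCC(N)=O)[C@H]2O[Si](C)(C)C(C)(C)C)c(=O)n(C)c1=O` gives 13500 nM. Within the data shown here, the only measured step is an at least 14-fold higher number from compound 1 to compound 2 (1.17 log units; beyond the scatter), with acetyl in place of carbamoylmethyl on an amine nitrogen. Compound 3 `C=C(C)C(=O)NC(=O)NC1=CS(=O)(=O)O[C@@]12[C@@H](CO[Si](C)(C)C(C)(C)C)O[C@@H](n1cc(C)c(=O)n(C)c1=O)[C@@H]2O[Si](C)(C)C(C)(C)C` carries ((1-methylethenyl)carbonyl)amino in place of methyl on a carbonyl carbon. That single large step shows that this part of compound 2 can move the read-out, but it gives no direct guide to the new group. A moderate move towards a lower number is expected, with the estimated step of an at least 2.0-fold lower number from compound 2 to compound 3 (0.30 log units; that floor lies within the scatter). Compound 3 is estimated at 100000 nM, with an expected range of 30000 nM to 200000 nM.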

Compound 3, half-maximal cytotoxic concentration: 1200 nM
Compound 3: the middle estimate sits 83-fold (1.92 log units) above what was measured, and the stated range ends above it.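

Replacing methyl with ((1-methylethenyl)carbonyl)amino on this carbonyl carbon gives an at least 160-fold lower number from compound 2 to compound 3 (2.22 log units; beyond the scatter) in this assay, so this position can move the read-out in the direction of less tolerated compound, not only towards more. This step starts from a limit and not a number, that of compound 2: the limit of > 200000 nM in this assay, at which 1 of the 3 values shown sits.

The new group also ends lower than the carbamoylmethyl of compound 1, with an 11-fold lower number from compound 1 to compound 3 (1.05 log units; beyond the scatter).

From the compounds shown here alone, whether the 1-methylethenyl end is what matters stays open. An isopropyl or a plain amine on that carbonyl carbon would separate that end from the added carbonyl.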